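The compounds below may be only part of what the source reports. "The series", "measured", "known", "first", "only" and "open" are said of these compounds alone.

Working notes on the series.

Three compounds carry measurements in a functional assay; a higher number here means a weaker inhibitor, a lower number a stronger inhibitor. Compound 1 `O=c1cc(/C=C/c2ccc(O)c(O)c2)oc2cc(O)ccc12` gives 18000 nM. Compound 2 `O=c1cc(/C=C/c2ccccc2)oc2cc(O)cc(O)c12` gives 5700 nM, the lowest of the three numbers, with compound 1 nearest and compound 3 furthest, both gaps beyond the scatter. Compound 3 `O=c1cc(/C=C/c2ccc(O)c(O)c2)oc2ccccc12` gives 31200 nM. How the cores of compound 2 and compound 3 differ is not broken down here. One single-site change is measured: hydroxy in place of hydrogen on an aromatic carbon, which gave a 1.7-fold lower number from compound 3 to compound 1 (0.24 log units; within the scatter), a step within the scatter.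

Compound 4 `O=c1cc(/C=C/c2ccc(O)cc2)oc2cc(O)cc(O)c12` is not yet measured in this assay. It differs from compound 2 by hydroxy in place of hydrogen on an aromatic carbon. This is the same kind of change as that from compound 3 to compound 1, but the surroundings differ: in compound 1 the hydroxy sits on a ring that is part of a fused or bridged system of two rings, meta to a fused ring and para to a fused ring, whereas in compound 4 it sits on a ring of carbon only, para to a large group. Because the earlier step of a 1.7-fold lower number from compound 3 to compound 1 (0.24 log units; within the scatter) stayed within the scatter, a step of about a 1.4-fold lower number from compound 2 to compound 4 (0.15 log units; within the scatter) is expected here as well. Compound 4 is therefore estimated at 4000 nM, with a likely range of 1500 nM to 12000 nM.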

Compound 4, half-maximal inhibitory concentration: 8500 nM
Beside the measured number, compound 4's estimate is 2.1-fold (0.33 log units) below it; the measured number falls inside the stated range.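

In this assay, hydroxy in place of hydrogen on an aromatic carbon, read here as phenyl to 4-hydroxyphenyl, gives a 1.5-fold higher number from compound 2 to compound 4 (0.17 log units; within the scatter). Set beside the earlier step on the other core, the two readings do not separate: the same change on two cores in this assay, a 1.7-fold lower number (0.24 log units; within the scatter) from compound 3 to compound 1 and a 1.5-fold higher number (0.17 log units; within the scatter) from compound 2 to compound 4, 2.6-fold (0.41 log units) apart, within the scatter of two such steps. In these two pairs the change therefore carried from one core to the other without a step beyond the scatter, but neither step fixes a direction, and two pairs with the hydroxy on different rings give no general rule for other cores in the series.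

Going by these compounds, what a methoxy group, an amine or a carboxylic acid would do in the place of this hydroxy remains open. Also open, on these data alone, is whether hydroxy at another place on the ring of carbon only would give a step of similar size.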